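This account rests on a few compounds, and the source may have more. Where it says the series, first, only, none or still open, it means among the compounds named here.

Measured in a functional assay on HeLa cells (Homo sapiens) for cytotoxicity, read by sulforhodamine B assay, with a stated time of 72 h; a higher number here means a weaker inhibitor, a lower number a stronger inhibitor:
- compound 1 `C=C1C(=O)O[C@@H]2CC(C)=C([C@@H](C)CCCOC(C)=O)[C@@H](OC(=O)COc3cccc(C(C)=O)c3)[C@H]12`: 38600 nM
- compound 2 `C=C1C(=O)O[C@@H]2CC(C)=C([C@@H](C)CCCOC(C)=O)[C@@H](OC(=O)COc3ccc(C(=O)OCCC)cc3)[C@H]12`: 22900 nM
- compound 3 `C=C1C(=O)O[C@@H]2CC(C)=C([C@@H](C)CCCOC(C)=O)[C@@H](OC(=O)COc3ccc([N+](=O)[O-])cc3[N+](=O)[O-])[C@H]12`: > 100000 nM, a limit of the assay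

Within the data shown here, compound 1 has only one neighbour with a true number, and that step is a 1.7-fold lower number from compound 1 to compound 2 (0.23 log units; within the scatter). Compound 3 reports only (the limit of > 100000 nM in this assay, at which 1 of the 3 values shown sits).

Compound 4 `C=C1C(=O)O[C@@H]2CC(C)=C([C@@H](C)CCCOC(C)=O)[C@@H](OC(=O)c3cccc(F)c3)[C@H]12` keeps the shared core and takes 3-fluorophenyl in place of (3-acetylphenoxy)methyl on a carbonyl carbon, (3-fluorophenyl in place of (3-acetylphenoxy)methyl on a carbonyl carbon). Among the measured compounds shown here, no measured step makes this exact change. The three measured steps alter only the aryl group on an oxygen on a saturated carbon, so they bear on it only indirectly.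

Two of them involve the 2,4-dinitrophenyl group of compound 3, namely an at least 2.5-fold higher number from compound 1 to compound 3 (0.41 log units; beyond the scatter) and an at least 4.3-fold higher number from compound 2 to compound 3 (0.64 log units; beyond the scatter). These moved beyond the scatter, but compound 4 does not carry that group. The exchange that led to compound 2 stayed within the scatter, at a 1.7-fold lower number from compound 1 to compound 2 (0.23 log units; within the scatter), and it is the closer guide.

On that basis, no step beyond the scatter is expected in this assay, although the uncertainty is wide. The expected step is a 1.5-fold lower number from compound 1 to compound 4 (0.19 log units; within the scatter). For compound 4 the estimated value is 25000 nM, with an expected range from 8000 nM to 70000 nM.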

Compound 4, half-maximal inhibitory concentration: 11800 nM
Compound 4: the middle estimate sits 2.1-fold (0.33 log units) above what was measured; the measured number falls inside the stated range.
By their numbers in this assay, from the lowest: compounds 4, 2 and 1 (each within the scatter of the next, the first and the last beyond it). At a limit, above all of these: compound 3.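

In this assay, among these compounds, the exchange gives a 3.3-fold lower number from compound 1 to compound 4 (0.51 log units; beyond the scatter) and is the first step in this set to reach a lower number beyond the scatter. Earlier steps altered only the aryl group on an oxygen on a saturated carbon, and the only one that ended at a lower number stayed within the scatter. This result shows that replacing the whole (3-acetylphenoxy)methyl group on the carbonyl carbon with 3-fluorophenyl is tolerated in this assay and moves the number down, but nothing given here explains the size of the step.

The step removes the phenoxy oxygen, the methylene and the acetyl group and adds a fluorine in a single exchange, so the compounds shown leave open which of these changes carries the difference. A plain phenyl or a (3-fluorophenoxy)methyl group on the same carbonyl carbon would help separate the effect of the fluorine from that of the shorter attachment, while a 3-chlorophenyl group would test whether the fluorine itself is needed.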